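Heptylsulfinyl in place of heptylamino on the shared core

This account rests on a few compounds, and the source may have more. Where it says the series, first, only, none or still open, it means among the compounds named here.

Of the compounds shown here, two have been measured in an assay on microsomes from liver for inhibition of sterol O-acyltransferase 1 (Rattus norvegicus); on this read-out lower numbers stand for stronger inhibition and higher numbers for weaker inhibition. Compound 1 `CCCCCCn1nc(-c2ccccc2)c(-c2ccccc2)cc1=O` gives 57000 nM in this assay. Compound 2 `CCCCCCCNc1cc(-c2ccccc2)c(-c2ccccc2)nn1` gives 55000 nM in this assay; it holds the lowest of the two numbers, and its nearest neighbour is compound 1, whose number differs from it only within the scatter, so the two values show no order between them. Among the compounds with values here, no step between measured compounds that differ in one place is available.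

Compound 3 `CCCCCCC[S+]([O-])c1cc(-c2ccccc2)c(-c2ccccc2)nn1` is the next compound to be measured in this assay. It differs from compound 2 by a group of 9 heavy atoms (7 carbon, 1 oxygen, 1 sulfur; no ring) in place of a group of 8 heavy atoms (7 carbon, 1 nitrogen; no ring), on an aromatic carbon, with the chain length kept the same.

Within the data shown here, with no measured pair of this kind to lean on, the step from compound 2 to compound 3 is expected to stay within the scatter, the estimate being a 1.1-fold lower number from compound 2 to compound 3 (0.04 log units; within the scatter). For compound 3 the expected value in this assay is 50000 nM, with a range from 15000 nM to 150000 nM.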

Compound 3, half-maximal inhibitory concentration: 77000 nM
Compound 3: the middle estimate sits 1.5-fold (0.19 log units) below what was measured; low and high end bracket the measured number.
By their numbers in this assay, from the lowest: compounds 2, 1 and 3 (each within the scatter of the next).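

In this assay, the heptylsulfinyl group in place of heptylamino on this aromatic carbon, with the chain length kept the same, gives a 1.4-fold higher number from compound 2 to compound 3 (0.15 log units; within the scatter), so this replacement cannot be told apart from repeated measurement on this read-out. The hydrogen-bond donor of heptylamino is absent from the entering group, and the two compounds still show no order between them, so within this single pair the read-out does not depend on that donor or on the nitrogen linking the chain to the shared core. No separate measurement of any property of either group accompanies this pair, and the step offers nothing further to interpret.

Within the data shown here, whether any group at this position can move the number beyond the scatter remains open, as this one pair tests only two linking groups on a heptyl chain. Heptyloxy, heptylthio and heptylsulfonyl at the same carbon, or a shorter or longer chain on the sulfinyl group, would show whether the linking atom or the chain governs the read-out in this series.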